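A few compounds are considered here, and "the series" means these few. Any claim that something is new, unique, unknown or untested is made for them only; others in the source may bear on it.

Measured in an ADME assay on MT4 cells (Homo sapiens) for cytotoxicity, read by MTT assay; a higher number here means that more compound is tolerated, a lower number that less compound is tolerated:
- compound 1 `Cc1ccc(NC(=O)CSc2nncnc2-c2cccc3ccccc23)c([N+](=O)[O-])c1`: 147000 nM
- compound 2 `O=C(CSc1nncnc1-c1cccc2ccccc12)Nc1ccccc1Br`: 87000 nM

Within the data shown here, compound 2 has only one neighbour to compare with, and the two numbers lie within the usual scatter of each other, so neither compound can be ranked above the other. The next compound, compound 3 `O=C(CSc1nncnc1-c1cccc2ccccc12)Nc1cccnc1Cl`, keeps the shared core and changes only the group on the amide-type nitrogen: 2-chloropyridin-3-yl in place of 2-bromophenyl on an amide-type nitrogen. A single measured step bears on this, one that also exchanges the group at that place: a 1.7-fold lower number from compound 1 to compound 2 (0.23 log units; within the scatter). That exchange left this assay essentially unmoved, so no step beyond the scatter is expected here, although one step is thin evidence. For compound 3 the estimated value is 110000 nM, with an expected range of 40000 nM to 300000 nM. The estimate means a 1.3-fold higher number from compound 2 to compound 3 (0.10 log units; within the scatter).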

Compound 3, half-maximal cytotoxic concentration: 44000 nM
Compound 3: middle estimate off by 2.5-fold (0.40 log units), on the high side; the range from low to high includes it.
By their numbers in this assay, from the lowest: compounds 3, 2 and 1 (each within the scatter of the next, the first and the last beyond it).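

In this assay, the group on the amide-type nitrogen now gives its first step beyond the scatter: a 3.3-fold lower number from compound 1 to compound 3 (0.52 log units; beyond the scatter) when 2-chloropyridin-3-yl replaces 4-methyl-2-nitrophenyl. The other exchange gives a 2.0-fold lower number from compound 2 to compound 3 (0.30 log units; within the scatter) and so cannot separate 2-chloropyridin-3-yl from 2-bromophenyl, which means that this position can shift how much compound the cells tolerate, but only compound 1 and compound 3 lie far enough apart to be ranked. No measurement is available that accounts for this shift. 

The compounds shown leave open how an unsubstituted phenyl, a cyclohexyl ring or a phenyl carrying a carboxylic acid would behave on this nitrogen. They also leave open whether 2-chloropyridin-3-yl would give a similar result on a different core.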